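This account rests on a few compounds, and the source may have more. Where it says the series, first, only, none or still open, it means among the compounds named here.

Compound 2, `COc1ccc2occ(CSC(=S)N3CCOCC3)c(=O)c2c1`, gives 4800 nM in a functional assay on HEp-2 cells (Homo sapiens) for antiproliferative activity, read by MTT assay, with a stated time of 72 h; on this read-out lower numbers stand for stronger inhibition and higher numbers for weaker inhibition.
Compound 3, `O=c1cc(CSC(=S)N2CCOCC2)oc2cc(Cl)ccc12`, gives 20600 nM in this assay.
Compound 1, `O=c1cc(CSC(=S)N2CCCC2)oc2cc(Cl)ccc12`, gives > 40000 nM in this assay, which is a limit of the assay and not a number.

Of the two numbers, compound 2 gives the lower and compound 3 the higher, a gap that lies beyond the scatter. How the core of compound 2 differs from the core of compound 3 is not broken down here.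

From compound 3 to compound 1 the change is pyrrolidin-1-yl in place of morpholin-4-yl on a thiocarbonyl carbon. That step gave an at least 1.9-fold higher number from compound 3 to compound 1 (0.28 log units; that floor lies within the scatter); it is known only as a floor because compound 1 sits at the limit of > 40000 nM in this assay, at which 1 of the 3 values shown sits.

Compound 4, `COc1ccc2occ(CSC(=S)N3CCCC3)c(=O)c2c1`, is not yet measured. From compound 2 it differs by pyrrolidin-1-yl in place of morpholin-4-yl on a thiocarbonyl carbon, the same change as from compound 3 to compound 1, made at the same place. Resting on an at least 1.9-fold higher number from compound 3 to compound 1 (0.28 log units; that floor lies within the scatter), the step expected in this assay is a 2.5-fold higher number from compound 2 to compound 4 (0.40 log units; beyond the scatter). Compound 4 is thus estimated at 12000 nM, expected between 5000 nM and 35000 nM.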

Compound 4, half-maximal inhibitory concentration: 3100 nM
Estimate against measurement, compound 4: 3.9-fold (0.59 log units) above, and the stated range ends above it.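

In this assay the change from morpholin-4-yl to pyrrolidin-1-yl on a thiocarbonyl carbon gave (a 1.5-fold lower number from compound 2 to compound 4 (0.19 log units; within the scatter)), so on the core of compound 2 it made no difference that stands clear of the scatter. The same change did not carry over as one step from one core to the other: the same change on two cores in this assay, an at least 1.9-fold higher number (0.28 log units; that floor lies within the scatter) from compound 3 to compound 1 and a 1.5-fold lower number (0.19 log units; within the scatter) from compound 2 to compound 4, at least 3.0-fold (0.47 log units) apart, beyond the scatter of two such steps. Going by these compounds, compound 1 gives > 40000 nM in this assay, a limit of the assay and not a number, and the true size of the gap therefore stays unknown, while two pairs do not show why the cores part or how the change would read on any further core.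

The compounds shown leave open whether other amines on the thiocarbonyl carbon, such as piperidin-1-yl or an open-chain diethylamino group, would follow either core. On these data alone, it also stays open how the change would read on a core carrying a fluoro group instead.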